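A few compounds are considered here, and "the series" means these few. Any claim that something is new, unique, unknown or untested is made for them only; others in the source may bear on it.

Measured compounds:
- compound 1 `CC(=O)OC[C@H]1O[C@H](OC[C@@H](Cn2cc(CN(c3nc(-c4cccc([N+](=O)[O-])c4)no3)C3CCCCC3)nn2)OC(C)=O)C=C[C@@H]1OC(C)=O` — > 200 ug/mL
- compound 2 `CC(=O)OC[C@H]1O[C@H](OC[C@@H](Cn2cc(CN(c3nc(-c4cccc(C)c4)no3)C3CCCCC3)nn2)OC(C)=O)C=C[C@@H]1OC(C)=O` — 39.2 ug/mL

In an ADME assay on HepG2 cells (Homo sapiens) for cytotoxicity, read by MTT assay, with a stated time of 48 h (a higher number here means that more compound is tolerated, a lower number that less compound is tolerated), compound 2 gives 39.2 ug/mL. Among the compounds with values here, that is the only plain number in the set. For compound 1 the result in this assay is a limit, > 200 ug/mL, not a number. Within the data shown here, the one step that can be read, an at least 5.1-fold lower number from compound 1 to compound 2 (0.70 log units; beyond the scatter), rests on that limit of > 200 ug/mL in this assay, at which 1 of the 2 values shown sits, and so is known only as a lower bound on its size.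

Compound 3 `CC(=O)OC[C@H]1O[C@H](OC[C@@H](Cn2cc(CN(c3nc(-c4ccccc4)no3)C3CCCCC3)nn2)OC(C)=O)C=C[C@@H]1OC(C)=O` differs from compound 2 by hydrogen in place of methyl on an aromatic carbon, on an aromatic carbon of a six-membered aromatic ring of carbon only. No measured step removes a methyl in this way; the only step shown concerns a nitro giving way to a methyl, which does not speak to this change. With nothing that bears on it, a step within the usual scatter is expected in this assay, with no clear direction, as a 1.1-fold higher number from compound 2 to compound 3 (0.06 log units; within the scatter). Compound 3 is therefore estimated at 45 ug/mL, expected to lie between 20 ug/mL and 120 ug/mL.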

Compound 3, half-maximal cytotoxic concentration: 19.9 ug/mL
Estimate against measurement, compound 3: 2.3-fold (0.35 log units) above; the measured number lies below the stated range.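

In this assay, the new step at the aromatic carbon meta to a large group, a 2.0-fold lower number from compound 2 to compound 3 (0.29 log units; within the scatter), stays within the scatter, so methyl and hydrogen at this place cannot be told apart. The earlier contrast between nitro and methyl now has a second partner, since hydrogen in place of nitro gives an at least 10-fold lower number from compound 1 to compound 3 (1.00 log units; beyond the scatter), which is beyond the scatter, so the nitro compound stands apart from both of the others. Compound 1 gives > 200 ug/mL, which is a limit and not a number, so the true size of this step remains unknown and only its lower bound can be read: the limit of > 200 ug/mL in this assay, at which 1 of the 3 values shown sits.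

The compounds shown leave open whether the separation belongs to the nitro group alone, or whether another group at this place, such as an amine, a nitrile or a carboxylic acid, would also stand apart from methyl and hydrogen. They also leave open whether the same contrast would hold with the nitro group on another carbon of the ring, and how far compound 1 really lies from the other two.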